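Swapping methoxy for bromo on the anilino ring

The compounds below may be only part of what the source reports. "The series", "measured", "known", "first", "only" and "open" are said of these compounds alone.

The measured compounds, each with its structure and value:
Compound 1, `Cc1ccc(NC2=CC(=O)c3nc4n(c3C2=O)[C@H]2OC[C@@H](O)[C@H]2OC4)cc1`, gives 3480 nM in a functional assay on ECa-109 cells for inhibition, with ECa-109 cell line (Homo sapiens) as the target, read by sulforhodamine B assay; a lower number here means a stronger inhibitor, a higher number a weaker inhibitor.
Compound 2, `O=C1C=C(Nc2ccccc2)C(=O)c2c1nc1n2[C@H]2OC[C@@H](O)[C@H]2OC1`, gives 4970 nM in this assay.
Compound 3, `COc1ccc(NC2=CC(=O)c3nc4n(c3C2=O)[C@H]2OC[C@@H](O)[C@H]2OC4)cc1`, is reported only as a limit, > 4000 nM, in this assay.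

All three share the same core and differ only in the group carried on the outer aromatic ring. The step of a 1.4-fold higher number from compound 1 to compound 2 (0.15 log units; within the scatter) is small; the step of an at least 1.1-fold higher number from compound 1 to compound 3 (0.06 log units; that floor lies within the scatter) is likewise small, and the step that the limit leaves unreadable from compound 2 to compound 3 cannot be sized because compound 3 sits at a limit, the point at which (the limit of > 4000 nM in this assay, at which 1 of the 3 values shown sits). On the numbers shown, compound 3 therefore stands no more potent than compound 1 and cannot be placed against compound 2 at all.

Compound 4, `O=C1C=C(Nc2ccc(Br)cc2)C(=O)c2c1nc1n2[C@H]2OC[C@@H](O)[C@H]2OC1`, has not yet been tested. It differs from compound 3 by bromo in place of methoxy on an aromatic carbon.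

The three measured steps all stay within the scatter, so no step beyond the scatter is expected in this assay for this change either. For compound 4 the expected step is a number no higher from compound 3 to compound 4 (the limit leaves the size open). Compound 4 is accordingly estimated at 4000 nM, with a range from 1500 nM to 10000 nM, and it may again come back only as a limit.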

Compound 4, half-maximal inhibitory concentration: 2850 nM
The estimate for compound 4 lay 1.4-fold (0.15 log units) above the measured number; measured number inside the range.
By their numbers in this assay, from the lowest: compounds 4, 1 and 2 (each within the scatter of the next).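

In this assay, among these compounds, the carbon of the outer ring that sits para to a large group now also carries a bromo with no step that stands out from the scatter: the comparison with the plain ring shows a 1.7-fold lower number from compound 2 to compound 4 (0.24 log units; within the scatter), and the comparison with the methyl group shows a 1.2-fold lower number from compound 1 to compound 4 (0.09 log units; within the scatter). Bromo, a single heavy atom, thus joins hydrogen and methyl as a third group at this carbon, and the values of these three compounds cannot be put in any order. The change from methoxy to bromo gives an at least 1.4-fold lower number from compound 3 to compound 4 (0.14 log units; that floor lies within the scatter), which is a floor and not a size, so compound 3 cannot be placed with the other three: the limit of > 4000 nM in this assay, at which 1 of the 4 values shown sits.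

Going by these compounds, it remains open whether any group at this carbon can move the number beyond the scatter, since every readable step here stays within it. An amine, a carboxylic acid or a longer chain such as butoxy at this carbon would test that, and a bromo on another carbon of the ring would show whether this position matters at all.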